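The compounds below may be only part of what the source reports. "The series", "measured", "known", "first", "only" and "open" are said of these compounds alone.

In an in vitro ADME assay on microsomes from liver (Mus musculus) for pharmacokinetics, read by LC-MS, with a stated time of 10 min, tested at 1 uM (a lower number here means slower removal, a higher number faster removal of the compound), three compounds of this series have been measured:

Compound 1 `Cc1ccc(NC(=O)[C@H]2CN(C)C[C@@H]2c2ccc(/C=C/C(=O)Nc3ccccc3N)cc2)cc1`: 62 mL/min/kg
Compound 2 `CN1C[C@H](C(=O)Nc2ccc(C(F)(F)F)cc2)[C@@H](c2ccc(/C=C/C(=O)Nc3ccccc3N)cc2)C1`: 23 mL/min/kg
Compound 3 `Cc1cc(NC(=O)[C@H]2CN(C)C[C@@H]2c2ccc(/C=C/C(=O)Nc3ccccc3N)cc2)ccc1F`: 62 mL/min/kg

Compound 2 stands lowest of the three in this assay. The step of a 2.7-fold lower number from compound 1 to compound 2 (0.43 log units; beyond the scatter) sets it apart from compound 1, and the step of a 2.7-fold higher number from compound 2 to compound 3 (0.43 log units; beyond the scatter) sets it apart from compound 3, while between compound 1 and compound 3 there is no change at the digits printed from compound 1 to compound 3 (within the scatter).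

Compound 4 `Cc1ccc(NC(=O)[C@H]2CN(C)C[C@@H]2c2ccc(/C=C/C(=O)Nc3ccccc3N)cc2)cn1` has not yet been measured. It differs from compound 2 in one place: 6-methylpyridin-3-yl in place of 4-(trifluoromethyl)phenyl on an amide-type nitrogen. Among the compounds with values here, two measured steps bear on this change. The step from compound 1 to compound 2 shows that trifluoromethyl in place of methyl brought a modest lowering, and the step from compound 2 to compound 3 shows that removing the 4-(trifluoromethyl)phenyl group brought a modest rise. Compound 4 carries a methyl group again, so a rise of about the size of a 2.7-fold higher number from compound 2 to compound 3 (0.43 log units; beyond the scatter) is expected, giving a 2.6-fold higher number from compound 2 to compound 4 (0.42 log units; beyond the scatter). Within the data shown here, no measured compound carries a ring nitrogen in this place, so that part of the change is untested. Compound 4 is therefore estimated at 60 mL/min/kg, with a range from 30 mL/min/kg to 120 mL/min/kg.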

Compound 4, clearance: 57 mL/min/kg
Compound 4: the middle estimate sits 1.1-fold (0.02 log units) above what was measured; the range from low to high includes it.
By their numbers in this assay, from the lowest: compound 2; then compounds 4, 1 and 3 (each within the scatter of the next).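

In this assay, compound 4 is the only compound shown with a ring nitrogen at this place, and that nitrogen leaves it level with the two other methyl-bearing compounds (a 1.1-fold lower number from compound 1 to compound 4 (0.04 log units; within the scatter); a 1.1-fold lower number from compound 3 to compound 4 (0.04 log units; within the scatter)). The 4-(trifluoromethyl)phenyl group of compound 2 still stands apart from the new group (a 2.5-fold higher number from compound 2 to compound 4 (0.39 log units; beyond the scatter)), so among these four compounds only the group without a ring methyl gives the low number, and none goes against this. Nothing shown accounts for this result.

From the compounds shown here alone, it remains open whether trifluoromethyl in place of methyl on the 6-methylpyridin-3-yl group would bring the lowering seen on the 4-methylphenyl group (a 2.7-fold lower number from compound 1 to compound 2 (0.43 log units; beyond the scatter)). Going by these compounds, how a chlorine, a methoxy group or an amine would read on this ring also remains open.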